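Swapping the Halogenated Ring in an Inactive Pair

A few compounds are considered here, and "the series" means these few. Any claim that something is new, unique, unknown or untested is made for them only; others in the source may bear on it.

Compound 1 `C=CCn1c(=O)/c(=C\c2ccc(F)c(Br)c2)[nH]c(=O)/c1=C\c1ccccc1OC`: "not active" (no number reported)
Compound 2 `C=CCn1c(=O)/c(=C\c2cc(OC)c(OC)c(OC)c2)[nH]c(=O)/c1=C\c1cccc(Br)c1`: "not active" (no number reported)
Compound 3 `COc1ccccc1/C=c1/[nH]c(=O)/c(=C\c2nc[nH]c2C(C)(C)C)[nH]c1=O`: 90 nM

In a functional assay on A549 cells (Homo sapiens) for cytotoxicity, read by CCK-8 assay, with a stated time of 72 h (on this read-out higher numbers stand for weaker inhibition and lower numbers for stronger inhibition), compound 1 gives "not active" (no number reported), so no single number places it on the scale; compound 2 gives "not active" (no number reported) as well. Among the measured compounds shown here, only compound 3 has a number, and in this assay compound 3 gives 90 nM, but its core differs from that of compound 1 in more than one place, so no single step connects them.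

Compound 4 `C=CCn1c(=O)/c(=C\c2cccc(Cl)c2Cl)[nH]c(=O)/c1=C\c1ccccc1OC` keeps the core of compound 1 with one change: 2,3-dichlorophenyl in place of 3-bromo-4-fluorophenyl on a double-bonded chain carbon bound to an aromatic carbon. For the measured compounds named here, with no measured step of this kind, the expectation leans on compound 1 alone, whose result is "not active" (no number reported); a change of this size is not expected to move the read-out far beyond the scatter. Compound 4 is therefore expected to give about 30000 nM, within 5000 nM to 100000 nM.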

Compound 4, half-maximal inhibitory concentration: 2300 nM
Estimate against measurement, compound 4: 13-fold (1.12 log units) above, and the stated range ends above it.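

Among the compounds shown here, compound 1 has no single number, so the change from compound 1 to compound 4 gives no step that can be read. From the compounds shown here alone, how far swapping this halogenated ring moves the read-out on the shared core remains open. No supporting evidence bears on this result.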